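This account rests on a few compounds, and the source may have more. Where it says the series, first, only, none or still open, it means among the compounds named here.

Notes on the series built on the shared core of compound 1 `COc1ccc(NCC(=O)Oc2ccc3c(C)cc(=O)oc3c2)cc1`, which carries 4-methoxyphenyl on the amine nitrogen. In a functional assay on the whole organism (strain Wistar albino) for inhibition, with Rattus norvegicus as the target, read by paw edema, with stated times of 30 min and 4 h, at a dose of 20 mg/kg by the oral route (on this read-out higher numbers stand for more inhibition at the one dose given (going by the name of the read-out) and lower numbers for less inhibition), compound 1 gives 28.8%. Compound 2 `Cc1cc(=O)oc2cc(OC(=O)CNc3nccs3)ccc12` has 1,3-thiazol-2-yl in place of 4-methoxyphenyl on the amine nitrogen, and in this assay compound 2 gives 32.3%. Among the compounds with values here, the one measured step, a number 3.5 percentage points higher from compound 1 to compound 2 (within the scatter), stays within the usual scatter. On the two numbers shown, compound 1 stands lowest, though the gap to its nearest neighbour compound 2 lies within the scatter, so the two are treated as indistinguishable.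

Compound 3 `Cc1cc(=O)oc2cc(OC(=O)CNc3ccc([N+](=O)[O-])cc3)ccc12` is not yet measured. Its change from compound 1: nitro in place of methoxy on an aromatic carbon. Within the data shown here, the only step that bears on it, a number 3.5 percentage points higher from compound 1 to compound 2 (within the scatter), exchanges the entire group on the amine nitrogen and does not move the read-out beyond the scatter; no measured step exchanges a substituent on the six-membered aromatic ring itself. With nothing in the data pointing to a larger move, the expected step of a number 1.2 percentage points higher from compound 1 to compound 3 (within the scatter) is one within the scatter, in no particular direction. Compound 3 is therefore estimated at 30%, with a range from 18% to 42%.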

Compound 3, a percentage reported as inhibition, in the whole organism at one dose (the size of the read-out at that dose, not a potency): 23.7%
For compound 3 the middle estimate is 6.3 percentage points above the measured one, and the stated range covers the measured number.
By their numbers in this assay, from the lowest: compounds 3, 1 and 2 (each within the scatter of the next).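

Within the data shown here, the change of nitro in place of methoxy is the first measured exchange on the six-membered aromatic ring of carbon only, at the place para to a large group, and in this assay it gives a number 5.1 percentage points lower from compound 1 to compound 3 (within the scatter). At this place, then, a group of 3 heavy atoms and 2 hydrogen-bond acceptors entering for one of 2 heavy atoms and 1 hydrogen-bond acceptor does not separate the two compounds at the one dose given, so methoxy and nitro cannot be told apart on this read-out. Nothing measured alongside these compounds bears on the reason for this result.

The compounds shown leave open whether another group at this same place, such as an amine, a carboxylic acid or chlorine, would move the read-out beyond the scatter. They also leave open whether a longer chain on the amine nitrogen would do so, and, with a single dose as the only read-out, how the compounds would compare in potency.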